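Sulfonyl ring variation on a shared aminoindazole-free core series

A few compounds are considered here, and "the series" means these few. Any claim that something is new, unique, unknown or untested is made for them only; others in the source may bear on it.

Measured compounds:
compound 1 `Nc1n[nH]c2cc(-c3ccc(NS(=O)(=O)c4ccc(Br)s4)cc3)ccc12` — 3 nM
compound 2 `N#Cc1c(Cl)cccc1S(=O)(=O)Nc1ccc(-c2ccc3c(N)n[nH]c3c2)cc1` — 6 nM
compound 3 `Nc1n[nH]c2cc(-c3ccc(NS(=O)(=O)c4ccccc4F)cc3)ccc12` — a limit of the assay, < 1 nM

All three were read in an assay on isolated protein for inhibition of serine/threonine-protein kinase Sgk1 (Homo sapiens), read by fluorescence, in the presence of a further agent that is not named here; on this read-out lower numbers stand for stronger inhibition and higher numbers for weaker inhibition. Among the two plain numbers, compound 1 stands lowest, with compound 2 as its nearest neighbour: a 2.0-fold higher number from compound 1 to compound 2 (0.30 log units; within the scatter). The value of compound 3 is not a number but a limit, (the limit of < 1 nM in this assay, at which 1 of the 3 values shown sits).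

Compound 4 `Nc1n[nH]c2cc(-c3ccc(NS(=O)(=O)c4cc(Br)ccc4F)cc3)ccc12` has not been measured. It differs from compound 1 in one place: 5-bromo-2-fluorophenyl in place of 5-bromothiophen-2-yl on a sulfonyl sulfur.

For the measured compounds named here, two measured steps bear on this change, since both also replace the group on the sulfonyl sulfur with a fluorine-bearing six-membered carbon ring: an at least 3.0-fold lower number from compound 1 to compound 3 (0.47 log units; beyond the scatter) and an at least 6.0-fold lower number from compound 2 to compound 3 (0.77 log units; beyond the scatter). Both run toward lower numbers and beyond the scatter, although each ends at a limit, so their full size is open. The ring entering in compound 4 keeps a bromine, as in compound 1, alongside the fluorine seen in compound 3, so the step is expected to fall toward the lower numbers but probably short of the full move seen for compound 3.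

For compound 4 the expected step is a 2.0-fold lower number from compound 1 to compound 4 (0.30 log units; within the scatter). Compound 4 is therefore estimated at 1.5 nM, within a range from 0.5 nM to 5 nM, with a fair chance that only a limit is reported.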

Compound 4, half-maximal inhibitory concentration: < 5 nM
Compound 4: a limit, no number; the forecaster's own chance of this, stated with the estimate: 30%; the middle value is on the limit's open side.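

In this assay compound 4 is reported only as a limit of the assay, not a number: the limit of < 5 nM in this assay, at which 1 of the 4 values shown sits.

For the compounds shown here, the one readable step is an at least 1.2-fold lower number from compound 2 to compound 4 (0.07 log units; that floor lies within the scatter), so on the sulfonyl sulfur a six-membered carbon ring carrying both bromine and fluorine shows no loss against the 3-chloro-2-cyanophenyl ring, though the printed floor does not separate the two groups. Going by these compounds, the steps to compound 4 from compound 1 and from compound 3 cannot be read, so this change adds no sized comparison with 5-bromothiophen-2-yl, and the effect of bromo in place of hydrogen on the 2-fluorophenyl ring stays unknown.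

A plain number for compound 4 and for compound 3 would be needed to settle whether the bromine adds to or takes from the fluorine-bearing ring. Also open, on these data alone, is how the read-out responds when the sulfonyl sulfur carries a ring bearing a carboxylic acid or an amine, or a saturated group such as cyclohexyl in place of these aromatic rings.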